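The compounds below may be only part of what the source reports. "The series", "measured", "known", "first", "only" and "open" are said of these compounds alone.

Notes on the series. Compound 1 `O=C(/C(=C\c1ccc(Br)cc1)SCc1ccc(Cl)cc1)c1ccc(Cl)cc1` and compound 2 `O=C(/C(=C\c1ccc(O)c([N+](=O)[O-])c1)SCc1ccc(Cl)cc1)c1ccc(Cl)cc1` share one core and differ on the double-bonded chain carbon bound to a double-bonded chain carbon. In a functional assay on DU-145 cells (Homo sapiens) for inhibition, read by trypan blue exclusion, with a stated time of 96 h (on this read-out higher numbers stand for weaker inhibition of growth and lower numbers for stronger inhibition of growth), compound 1 gives 1000 nM, while compound 2 gives 10000 nM. Among the measured compounds shown here, the single measured step, a 10-fold higher number from compound 1 to compound 2 (1.00 log units; beyond the scatter), places compound 2 at the highest of the two numbers so far, with compound 1 as its only neighbour.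

Compound 3 `O=C(/C(=C\c1ccc(O)cc1)SCc1ccc(Cl)cc1)c1ccc(Cl)cc1` is not yet measured. Against compound 2 the change is hydrogen in place of nitro on an aromatic carbon, leaving the hydroxy group in place on the same ring. For the measured compounds named here, the only step that bears on it is a 10-fold higher number from compound 1 to compound 2 (1.00 log units; beyond the scatter), but that step swapped the whole 4-bromophenyl for the 4-hydroxy-3-nitrophenyl, so the share of the nitro alone in that change cannot be read from it. The step from compound 2 to compound 3 is therefore expected to be small to modest, most likely toward a lower number, with the direction not secure. Compound 3 is expected near 5000 nM in this assay, within 1500 nM to 15000 nM, meaning an estimated step of a 2.0-fold lower number from compound 2 to compound 3 (0.30 log units; within the scatter).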

Compound 3, concentration for 50% growth inhibition: 10000 nM
Compound 3: middle estimate off by 2.0-fold (0.30 log units), on the low side, within the range that was stated.
By their numbers in this assay, from the lowest: compound 1; then compounds 2 and 3 (each within the scatter of the next).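

In this assay, hydrogen in place of nitro on the aromatic carbon ortho to a hydroxy group gives no change at the digits printed from compound 2 to compound 3 (within the scatter), so with the hydroxy group in place, the nitro group makes no readable difference at this position. This separates the two parts of the earlier exchange: hydroxy in place of bromo alone gives a 10-fold higher number from compound 1 to compound 3 (1.00 log units; beyond the scatter), matching in size a 10-fold higher number from compound 1 to compound 2 (1.00 log units; beyond the scatter) seen when the whole 4-bromophenyl was replaced, and in these three compounds the full difference therefore goes with the hydroxy-for-bromo change. No measurement at hand explains this result.

The compounds shown leave open whether an amine or a methoxy group on the aromatic carbon carrying the hydroxy group would give a number close to that of compound 3 at 10000 nM or to that of compound 1 at 1000 nM. They also leave open whether a nitro group would be equally without readable effect on the ring of compound 1, with the bromo group kept.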